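The compounds below may be only part of what the source reports. "The series", "measured", "known", "first", "only" and "open" are said of these compounds alone.

Compound 1, `O=C(Nc1ccccc1)Nc1cccc(-c2nc(-c3ccc(NC(=O)c4cccnc4)cc3Cl)no2)c1`: in a functional assay on MDA-MB-231 cells (Homo sapiens) for antiproliferative activity, read by MTT assay, with a stated time of 72 h (a lower number here means a stronger inhibitor, a higher number a weaker inhibitor), compound 1 gives only a limit, > 10000 nM. Compound 2, `CS(=O)(=O)Nc1ccc(NC(=O)Nc2cccc(-c3nc(-c4ccc(NC(=O)c5cccnc5)cc4Cl)no3)c2)cc1Cl`: in this assay compound 2 gives 600 nM.

Going by the values given here, compound 2 holds the only true number here; the other value is a limit (the limit of > 10000 nM in this assay, at which 1 of the 2 values shown sits). Compound 3, `CS(=O)(=O)Nc1ccc(NC(=O)Nc2cccc(-c3nc(-c4ccc(NC(=O)c5cccnc5)cc4Cl)no3)c2)cc1Br`, differs from compound 2 by bromo in place of chloro on an aromatic carbon. Among the compounds with values here, the one measured step, an at least 16-fold lower number from compound 1 to compound 2 (1.22 log units; beyond the scatter), swapped a whole aryl group and so tells little about exchanging one halogen for another. A step of no size beyond the scatter is expected, no change at the digits printed from compound 2 to compound 3 (within the scatter). Compound 3 is therefore estimated at 600 nM, between 250 nM and 1500 nM.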

Compound 3, half-maximal inhibitory concentration: 700 nM
The estimate for compound 3 lay 1.2-fold (0.07 log units) below the measured number; low and high end bracket the measured number.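

At this position, ortho to a methanesulfonamido group, bromo and chloro cannot be told apart in this assay: a 1.2-fold higher number from compound 2 to compound 3 (0.07 log units; within the scatter). The large gain over plain phenyl survives the exchange, an at least 14-fold lower number from compound 1 to compound 3 (1.15 log units; beyond the scatter), so it does not depend on chloro alone. The size of that step rests on a limit and not a true number: the limit of > 10000 nM in this assay, at which 1 of the 3 values shown sits.

Going by these compounds, what a methyl group, a methoxy group or plain hydrogen would give at this position remains open. So does how much of the gain belongs to the methanesulfonamido group and how much to the halogen.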